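A few compounds are considered here, and "the series" means these few. Any claim that something is new, unique, unknown or untested is made for them only; others in the source may bear on it.

Compound 1 `COc1ccc(C[C@H]2COC(=O)[C@@H]2Cc2ccc(OCC(=O)N3CCCCC3)c(OC)c2)cc1OC` is measured in an ADME assay on HeLa cells (Homo sapiens) for cytotoxicity, read by MTT assay (on this read-out lower numbers stand for stronger inhibition and higher numbers for weaker inhibition), at 293000 nM. Compound 2 `COc1ccc(C[C@H]2COC(=O)[C@@H]2Cc2ccc(OCC(=O)Nc3ccccc3)c(OC)c2)cc1OC` gives only a limit of the assay in this assay, namely >= 600000 nM. The step of an at least 2.0-fold higher number from compound 1 to compound 2 (0.31 log units; beyond the scatter) is known only as a bound, since compound 2 sits at the limit of >= 600000 nM in this assay, at which 1 of the 2 values shown sits. Compound 3 `COc1ccc(C[C@H]2COC(=O)[C@@H]2Cc2ccc(OCc3cn(-c4cccc(Cl)c4)nn3)c(OC)c2)cc1OC` carries 1-(3-chlorophenyl)-1H-1,2,3-triazol-4-yl in place of phenylcarbamoyl on a saturated chain carbon bound to an oxygen on an aromatic ring. Going by the values given here, no measured step covers this change; the single step known exchanges the amine on the carbonyl and says nothing about a triazole. The step of an at least 1.2-fold lower number from compound 2 to compound 3 (0.07 log units; that floor lies within the scatter) is therefore expected to lie within the scatter. Compound 3 is estimated in this assay at 500000 nM, within 200000 nM to 1200000 nM.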

Compound 3, half-maximal inhibitory concentration: 493000 nM
For compound 3 the middle estimate is 1.0-fold (0.01 log units) above the measured one; low and high end bracket the measured number.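

The position on a saturated chain carbon bound to an oxygen on an aromatic ring also takes a group without a carbonyl, and in this assay the triazole stays within the scatter of the piperidine amide (a 1.7-fold higher number from compound 1 to compound 3 (0.23 log units; within the scatter)). Against the anilide, the change gives only a bound whose floor lies within the scatter (an at least 1.2-fold lower number from compound 2 to compound 3 (0.08 log units; that floor lies within the scatter)). That bound rests on a limit of the assay for compound 2: the limit of >= 600000 nM in this assay, at which 1 of the 3 values shown sits.

From the compounds shown here alone, what the chlorine on the phenyl ring contributes stays open. So does what a carboxylic acid or an amine would give at this place.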